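The compounds below may be only part of what the source reports. "The series", "measured", "known", "first", "only" and "open" are said of these compounds alone.

Compound 1 `O=C1/C(=N\Nc2ccccc2)c2ccccc2N1Cc1cn(O[C@@H]2O[C@H](CO)[C@H](O)[C@H](O)[C@H]2O)nn1` is the parent of this small series. In an ADME assay on Vero cells (Chlorocebus sabaeus) for cytotoxicity, read by fluorescence and resazurin assay, with a stated time of 3 days (a lower number here means that less compound is tolerated, a higher number that more compound is tolerated), compound 1 gives 83400 nM. Compound 2 `O=C1/C(=N\Nc2ccc(F)cc2)c2ccccc2N1Cc1cn(O[C@@H]2O[C@H](CO)[C@H](O)[C@H](O)[C@H]2O)nn1` differs from it only by a 1.1-fold higher number from compound 1 to compound 2 (0.04 log units; within the scatter), and in this assay compound 2 gives 92100 nM. The two numbers sit close together, so compound 2 and compound 1 cannot be told apart on this measure.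

Compound 3 `O=C1/C(=N\Nc2cccc(Cl)c2)c2ccccc2N1Cc1cn(O[C@@H]2O[C@H](CO)[C@H](O)[C@H](O)[C@H]2O)nn1` is the next member, and it changes compound 2 as follows: 3-chlorophenyl in place of 4-fluorophenyl on an amine nitrogen. Within the data shown here, the only measured step, from a hydrogen to a fluorine, is not the same kind of change as swapping one halogenated phenyl for another, so it offers loose guidance at best. It suggests that small changes on this outer ring leave the tolerated concentration roughly where it is. Compound 3 is therefore expected to give about 88000 nM, with a likely range from 44000 nM to 176000 nM. The expected step is a 1.0-fold lower number from compound 2 to compound 3 (0.02 log units; within the scatter), no more than the usual scatter.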

Compound 3, half-maximal cytotoxic concentration: 84500 nM
For compound 3 the middle estimate is 1.0-fold (0.02 log units) above the measured one; low and high end bracket the measured number.
By their numbers in this assay, from the lowest: compounds 1, 3 and 2 (each within the scatter of the next).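

Replacing 4-fluorophenyl with 3-chlorophenyl on this amine nitrogen gives a 1.1-fold lower number from compound 2 to compound 3 (0.04 log units; within the scatter) in this assay, so these two halogenated rings cannot be told apart here. Set against the unsubstituted phenyl, the chlorine gives a 1.0-fold higher number from compound 1 to compound 3 (0.01 log units; within the scatter), which means the earlier result with fluorine is now joined by a second halogen that also leaves the number within the scatter. Nothing available explains why these three compounds cannot be separated.

Both the halogen and its printed ring position differ between compound 2 and compound 3, so 3-fluorophenyl and 4-chlorophenyl would be needed to consider each alone. On these data alone, it also remains open whether a non-halogen group on this phenyl ring, such as a carboxylic acid or an amine, would stay within the same narrow band.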